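Replacing the Carbonyl Group of Compound 3

The compounds below may be only part of what the source reports. "The series", "measured", "known", "first", "only" and "open" are said of these compounds alone.

Compound 1 `CNC(=O)NCc1nc(-c2ccc(OC)cc2)c(-c2ccc(OC)cc2)s1`: 22 nM
Compound 2 `COc1ccc(-c2nc(C(=O)N(C)C)sc2-c2ccc(OC)cc2)cc1`: < 100 nM (a limit)
Compound 3 `COc1ccc(-c2nc(C(=O)N=C(N)N)sc2-c2ccc(OC)cc2)cc1`: > 100 nM (a limit)

In a functional assay with Oryctolagus cuniculus as the target (on this read-out lower numbers stand for stronger inhibition and higher numbers for weaker inhibition), compound 3 gives > 100 nM, which is a limit and not an exact number. Compound 4 `COc1ccc(-c2nc(C(=O)N3CCCCC3CCO)sc2-c2ccc(OC)cc2)cc1`, not yet measured, instead carries 2-(2-hydroxyethyl)piperidin-1-yl on the carbonyl carbon: a group of 9 heavy atoms (7 carbon, 1 nitrogen, 1 oxygen; one six-membered non-aromatic ring with 1 hetero atom) in place of a group of 4 heavy atoms (1 carbon, 3 nitrogen; no ring), on a carbonyl carbon. For the measured compounds named here, two measured steps bear on this change. The closest is a number no lower from compound 2 to compound 3 (the limit leaves the size open), at the same carbonyl carbon. The other is an at least 4.5-fold higher number from compound 1 to compound 3 (0.65 log units; beyond the scatter), which lies beyond the scatter. Together they suggest that the group on compound 3 does not favour strong inhibition, so a move to a lower number is expected, though its size is uncertain. The expected change is an at least 1.6-fold lower number from compound 3 to compound 4 (0.22 log units; that floor lies within the scatter). For compound 4 the estimated value is 60 nM, with an expected range of 10 nM to 400 nM.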

Compound 4, half-maximal inhibitory concentration: 45 nM
Estimate against measurement, compound 4: 1.3-fold (0.12 log units) above; measured number inside the range.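

In this assay the carbonyl carbon takes 2-(2-hydroxyethyl)piperidin-1-yl well, with an at least 2.2-fold lower number from compound 3 to compound 4 (0.34 log units; beyond the scatter) as the step beyond the usual scatter. For the compounds shown here, compound 4 therefore gives the first exact value for a group on this carbonyl carbon, so a group with a six-membered ring is tolerated here. The step from compound 2 to compound 4 cannot be read because compound 2 is known only as a limit: the limit of < 100 nM in this assay, at which 1 of the 4 values shown sits.

From the compounds shown here alone, the ring and the hydroxyethyl chain enter together, so their separate contributions stay open. Plain piperidin-1-yl, without the chain, would separate them.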